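Swapping phenoxy for dimethylamino in the series

This account rests on a few compounds, and the source may have more. Where it says the series, first, only, none or still open, it means among the compounds named here.

In a functional assay on T47D cells (Homo sapiens) for inhibition, read by sulforhodamine B assay, with a stated time of 48 h (a higher number here means a weaker inhibitor of growth, a lower number a stronger inhibitor of growth), compound 1 `COc1cc(C)cc(-c2nn(CC#N)cc2-c2ccc(-c3cccc(C(C)=O)c3)nc2)c1` gives 2230 nM. Compound 2 `Cc1cc(O)cc(-c2nn(CC#N)cc2-c2ccnc(-c3ccc(Oc4ccccc4)cc3)c2)c1` gives 2040 nM in this assay; the two numbers lie within the scatter of each other, so compound 2 stands level with compound 1 and no order between them can be read. Compound 3 `Cc1cc(O)cc(-c2nn(CC#N)cc2-c2ccnc(-c3ccc(N(C)C)cc3)c2)c1` carries dimethylamino in place of phenoxy on an aromatic carbon, dimethylamino in place of phenoxy on an aromatic carbon. For the measured compounds named here, no measured pair shows this change, so for this assay a step from compound 2 to compound 3 of no more than the scatter is expected, with the direction open. Compound 3 is expected at 2500 nM, between 800 nM and 8000 nM, an estimated step of a 1.2-fold higher number from compound 2 to compound 3 (0.09 log units; within the scatter).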

Compound 3, concentration for 50% growth inhibition: 2590 nM
For compound 3 the middle estimate is 1.0-fold (0.02 log units) below the measured one; the measured number falls inside the stated range.
By their numbers in this assay, from the lowest: compounds 2, 1 and 3 (each within the scatter of the next).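

In this assay this first pair at the position gives a 1.3-fold higher number from compound 2 to compound 3 (0.10 log units; within the scatter) and stays within the scatter, so dimethylamino and phenoxy on this aromatic carbon, para to a large group, cannot be told apart. The six-membered aromatic ring of carbon only in phenoxy is therefore not needed to hold growth inhibition at the level of compound 2. No supporting data bear on why the two compounds stand level. On these data alone, whether a primary amine or a carboxylic acid at this place would move the number beyond the scatter remains open.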